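Replacing Methylsulfanyl with Aminoamino on a Thiophene Analogue

A few compounds are considered here, and "the series" means these few. Any claim that something is new, unique, unknown or untested is made for them only; others in the source may bear on it.

Compound 1, `CSc1nc(-c2cccs2)c(C#N)c(=O)n1C`, gives 83 ug/mL in a functional assay on microsomes for inhibition, with a stated time of 1 h; a lower number here means a stronger inhibitor, a higher number a weaker inhibitor.
Compound 2, `CSc1nc(-c2ccccc2O)c(C#N)c(=O)n1C`, gives 44 ug/mL in this assay.
Compound 3, `Cn1c(NN)nc(-c2ccccc2O)c(C#N)c1=O`, gives 34 ug/mL in this assay.

Compound 1 has the highest of the three numbers, and compound 2 is its nearest neighbour; the difference between the two cores is not broken down here. Between compound 2 and compound 3 there is one change, (aminoamino in place of methylsulfanyl on an aromatic carbon), and it gave the step of a 1.3-fold lower number from compound 2 to compound 3 (0.11 log units; within the scatter).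

Compound 4, `Cn1c(NN)nc(-c2cccs2)c(C#N)c1=O`, has not yet been measured. It arises from compound 1 by aminoamino in place of methylsulfanyl on an aromatic carbon. Going by the values given here, this is the same kind of change as the one from compound 2 to compound 3: the same group leaves, the same group enters, and the place agrees except that the carbon in compound 4 is meta to a thiophen-2-yl group (5 heavy atoms), whereas in compound 3 it is meta to a group of 7 heavy atoms.

Because the earlier step was a 1.3-fold lower number from compound 2 to compound 3 (0.11 log units; within the scatter), a step of similar size is expected in this assay: a 1.3-fold lower number from compound 1 to compound 4 (0.11 log units; within the scatter). Compound 4 is therefore estimated at 64 ug/mL, most likely between 35 ug/mL and 120 ug/mL.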

Compound 4, half-maximal inhibitory concentration: 68 ug/mL
The estimate for compound 4 lay 1.1-fold (0.03 log units) below the measured number; the measured number falls inside the stated range.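

In this assay, putting aminoamino in place of methylsulfanyl on the core of compound 1 gave a 1.2-fold lower number from compound 1 to compound 4 (0.09 log units; within the scatter). Compared with the same change on the core of compound 2, the new step agrees with the earlier one: the same change on two cores in this assay, a 1.3-fold lower number (0.11 log units; within the scatter) from compound 2 to compound 3 and a 1.2-fold lower number (0.09 log units; within the scatter) from compound 1 to compound 4, 1.1-fold (0.03 log units) apart, within the scatter of two such steps. On these two cores the change therefore behaves alike, with neither step standing out from the scatter, but this does not show that the change itself moves the number in either direction, and two cores are too few to support a rule for the whole series.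

The compounds shown leave open whether a different group on this aromatic carbon, such as a plain amine, a carboxylic acid or a longer chain, would give a step beyond the scatter. They also leave open whether aminoamino in place of methylsulfanyl would give a step of similar size on cores other than these two.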